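Benzylic methyl on the quinolinyl analogue: a step without precedent

The compounds below may be only part of what the source reports. "The series", "measured", "known", "first", "only" and "open" are said of these compounds alone.

Measured compounds and values in a functional assay on HL-60 cells (Homo sapiens) for cytotoxicity, read by MTT assay, with a stated time of 72 h, tested at 5 uM; a lower number here means a stronger effect, a higher number a weaker effect of the compound at the concentration tested:
- compound 1, `O=C1/C(=C\c2cccnc2)c2ccccc2N1Cc1ccccc1`: 25.4%
- compound 2, `O=C1/C(=C\c2ccc3ccccc3n2)c2ccccc2N1Cc1ccccc1`: 12.2%

For the measured compounds named here, of the two measured compounds, compound 2 gives the lower number in this assay, and its gap to compound 1 lies beyond the usual scatter; with only two compounds no wider pattern can be claimed. Compound 3, `CC(c1ccccc1)N1C(=O)/C(=C\c2ccc3ccccc3n2)c2ccccc21`, has not been measured. Relative to compound 2 the difference is methyl in place of hydrogen on a saturated chain carbon bound to an amide-type nitrogen in a ring and an aromatic carbon. Going by the values given here, no measured pair shows this change, so its effect on this assay is unknown. The change is small in what it counts, and nothing in the measured data points to a direction. The expectation is therefore that the step from compound 2 to compound 3 stays near zero or, at most, reaches a modest weakening, with a number 4.8 percentage points higher from compound 2 to compound 3 (within the scatter) as the estimated step. For compound 3 the value in this assay is expected to be about 17%, within a range from 5% to 38%.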

Compound 3, a percentage reported as activity, at one concentration (the size of the read-out at that concentration, not a potency): 18.5%
For compound 3 the middle estimate is 1.5 percentage points below the measured one; low and high end bracket the measured number.
By their numbers in this assay, from the lowest: compounds 2, 3 and 1 (each within the scatter of the next, the first and the last beyond it).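

In this assay, for the compounds shown here, the change from benzyl to 1-phenylethyl gives the first direct reading at this position: a number 6.3 percentage points higher from compound 2 to compound 3 (within the scatter) for methyl in place of hydrogen on a saturated chain carbon bound to an amide-type nitrogen in a ring and an aromatic carbon. Compound 2 at 12.2% and compound 3 at 18.5% therefore cannot be separated in this read-out, so this single added methyl shows no effect beyond the scatter at the one concentration tested, although one pair sets no trend for the position. No supporting evidence is available to explain this outcome.

The compounds shown leave open whether a longer chain such as ethyl, or a polar group such as a primary amine or a carboxylic acid, on the same carbon would also stay within the scatter of compound 2. They also leave open whether the same methyl would give a similar step on the core of compound 1, and whether a result at one concentration would hold across a full concentration range.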